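The compounds below may be only part of what the source reports. "The series", "measured", "known", "first", "only" and "open" are said of these compounds alone.

In a functional assay on SiHa cells (Homo sapiens) for inhibition, read by MTT assay (on this read-out higher numbers stand for weaker inhibition and lower numbers for stronger inhibition), compound 1 (`CC1(C)C2CCC1(C)C(OC(=O)/C=C/c1ccc(O)c(O)c1[N+](=O)[O-])C2`) gives 51800 nM and compound 2 (`CC1(C)C2CCC1(C)C(OC(=O)/C=C/c1cc(O)c(O)c(Br)c1)C2`) gives 29000 nM. These two values lie within the usual scatter of each other, so compound 2 stands level with compound 1 on the numbers available. Compound 3 (`CC1(C)C2CCC1(C)C(OC(=O)/C=C/c1ccc(O)c(O)c1)C2`) differs from compound 2 by hydrogen in place of bromo on an aromatic carbon. Going by the values given here, no measured pair shows this change, so only a modest move toward a higher number in this assay is expected, perhaps none beyond the scatter. The expected step is a 1.4-fold higher number from compound 2 to compound 3 (0.14 log units; within the scatter). For compound 3 the estimated value is 40000 nM, within an expected range of 15000 nM to 100000 nM.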

Compound 3, half-maximal inhibitory concentration: 73700 nM
For compound 3 the middle estimate is 1.8-fold (0.27 log units) below the measured one; measured number inside the range.
By their numbers in this assay, from the lowest: compounds 2, 1 and 3 (each within the scatter of the next, the first and the last beyond it).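

In this assay, hydrogen in place of bromo on this aromatic carbon, ortho to a hydroxy group, weakens inhibition beyond the scatter (a 2.5-fold higher number from compound 2 to compound 3 (0.41 log units; beyond the scatter)), so bromo here holds a modest but real edge over hydrogen. Hydrogen in place of nitro on an aromatic carbon stays within the scatter (a 1.4-fold higher number from compound 1 to compound 3 (0.15 log units; within the scatter)), so that change shows no clear difference. Nothing measured here accounts for the bromo step. On these data alone, whether chloro, methyl or methoxy on this carbon would match bromo stays open. So does whether an amine there would change the number at all.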